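A few compounds are considered here, and "the series" means these few. Any claim that something is new, unique, unknown or untested is made for them only; others in the source may bear on it.

Compound 1 `O=C(Nc1cccc(C(F)(F)F)c1)Nc1nnc(Sc2ncnc3scc(-c4ccncc4)c23)s1` belongs to a set of three ureas that share one core and differ only in the aryl group on the amide-type nitrogen. In a functional assay on HUVEC cells (Homo sapiens) for antiproliferative activity, read by MTT assay, with a stated time of 48 h (a higher number here means a weaker inhibitor, a lower number a stronger inhibitor), compound 1 gives 22400 nM, the second highest of the three numbers. Compound 2 `Cc1ccc(NC(=O)Nc2nnc(Sc3ncnc4scc(-c5ccncc5)c34)s2)cc1` gives 19300 nM in this assay, and compound 3 `O=C(Nc1ccc(F)cc1)Nc1nnc(Sc2ncnc3scc(-c4ccncc4)c23)s1` gives 28300 nM. The steps among them are small: a 1.2-fold lower number from compound 1 to compound 2 (0.06 log units; within the scatter), a 1.3-fold higher number from compound 1 to compound 3 (0.10 log units; within the scatter) and a 1.5-fold higher number from compound 2 to compound 3 (0.17 log units; within the scatter), each within the scatter, so no aryl change so far has moved the number in a way that can be trusted.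

Compound 4 `O=C(Nc1ccc(Cl)c(Cl)c1)Nc1nnc(Sc2ncnc3scc(-c4ccncc4)c23)s1` carries the change (3,4-dichlorophenyl in place of 3-(trifluoromethyl)phenyl on an amide-type nitrogen). It is another exchange of one substituted phenyl for another on the same nitrogen, which is the kind of step that has so far stayed within the scatter in all three measured pairs. Compound 4 is therefore expected to give an estimated step of a 1.0-fold lower number from compound 1 to compound 4 (0.01 log units; within the scatter) in this assay, which is no shift beyond the scatter. The expected value for compound 4 is 22000 nM, with a range from 10000 nM to 48000 nM.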

Compound 4, half-maximal inhibitory concentration: 7800 nM
Compound 4: the middle estimate sits 2.8-fold (0.45 log units) above what was measured, outside the stated range (below it).
By their numbers in this assay, from the lowest: compound 4; then compounds 2, 1 and 3 (each within the scatter of the next).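

In this assay the aryl group on the amide-type nitrogen proves able to move the number beyond the scatter, which none of the earlier exchanges did: 3,4-dichlorophenyl gives a 2.9-fold lower number from compound 1 to compound 4 (0.46 log units; beyond the scatter) and a 2.5-fold lower number from compound 2 to compound 4 (0.39 log units; beyond the scatter) and a 3.6-fold lower number from compound 3 to compound 4 (0.56 log units; beyond the scatter), all modest steps. Compound 4 thus stands apart as the strongest inhibitor of the four, while 3-(trifluoromethyl)phenyl, 4-methylphenyl and 4-fluorophenyl remain within the scatter of one another. No measurement shown here explains why this change has that effect.

The compounds shown do not tell whether both chlorines are needed, as no phenyl carrying a single chlorine is among them. They also leave open how the number would respond to a methoxy group, an amine or a carboxylic acid on this phenyl ring.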